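From isopropylsulfanyl to propoxy in a cytotoxicity assay

The compounds below may be only part of what the source reports. "The series", "measured", "known", "first", "only" and "open" are said of these compounds alone.

Measured in an ADME assay on CCRF-HSB-2 cells (Homo sapiens) for cytotoxicity, with a stated time of 7 days; a lower number here means that less compound is tolerated, a higher number that more compound is tolerated:
Compound 1 `Nc1nc(NC2CCCCC2)c2ncn(/C=C3/CC3(CO)CO)c2n1` gives > 20000 nM (a limit of the assay)
Compound 2 `CC(C)Sc1nc(N)nc2c1ncn2/C=C1/CC1(CO)CO` gives 94000 nM

Of these two results, only compound 2 has an actual number; the result for compound 1 is a limit. Among the measured compounds shown here, the one measured step that the limit leaves unreadable from compound 1 to compound 2 therefore offers no size to carry forward. For the measured compounds named here, compound 3 `CCCOc1nc(N)nc2c1ncn2/C=C1/CC1(CO)CO` has propoxy in place of isopropylsulfanyl on an aromatic carbon as its only difference from compound 2. In this assay the starting point for this change is compound 2 at 94000 nM. With nothing measured to suggest a shift, no step beyond the scatter is expected for this change. The expected step is a 1.3-fold lower number from compound 2 to compound 3 (0.13 log units; within the scatter) by this estimate. For compound 3 the estimated value is 70000 nM (expected range 20000 nM to 200000 nM).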

Compound 3, half-maximal cytotoxic concentration: > 20000 nM
Compound 3 ended at the assay's limit; the forecaster's own chance of this, stated with the estimate: 40%; the middle value is on the limit's open side.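

Among the compounds shown here, compound 3 gives > 20000 nM, which is a limit of the assay, so no step from compound 1 or compound 2 to compound 3 can be read. The compounds shown leave open how propoxy and isopropylsulfanyl compare in this assay.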